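The source may report more compounds than this note shows. Statements on the series, on what has been measured and on what is new or still open speak of the compounds shown alone.

The measured compounds are compound 1 `CC1=C(C(=O)OCC(C)C)C(c2cccs2)NC(=O)N1` with 25% in an assay on membranes from CHO cells for displacement of a labelled ligand from adenosine receptor A1 (Homo sapiens), read by scintillation counting, with a stated time of 60 min, tested at 1 uM (on this read-out higher numbers stand for more inhibition at the one concentration tested (going by the name of the read-out) and lower numbers for less inhibition), compound 2 `CC1=C(C(=O)OCC(C)C)C(c2cccs2)NC(=O)N1C` with 9%, and compound 3 `CCSC(=O)C1=C(C)NC(=O)NC1c1ccoc1` with 3%.

Compound 1 stands highest of the three numbers. Among the measured compounds shown here, the only step between compounds that differ in a single place is a number 16 percentage points lower from compound 1 to compound 2 (beyond the scatter), where a methyl replaces a hydrogen on an amide-type nitrogen in a ring. Compound 3 differs from compound 1 in more than one place, so its value stands on its own without a step to the others. Compound 4 `CCC(C)OC(=O)C1=C(C)NC(=O)NC1c1cccs1` keeps every atom of compound 1 but joins them differently: sec-butyl in place of isobutyl on an oxygen next to a carbonyl group. For the measured compounds named here, the one measured step, that from compound 1 to compound 2, concerns the ring nitrogen rather than the chain that changes here, so no measured step bears directly on this change, and the data give no reason to expect a shift in either direction. The account therefore expects a step of no change at the digits printed from compound 1 to compound 4 (within the scatter) that stays within the scatter. Compound 4 is estimated at 25%, with a range from 10% to 40%.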

Compound 4, a percentage reported as inhibition, at one concentration (the size of the read-out at that concentration, not a potency): 5%
Beside the measured number, compound 4's estimate is 20 percentage points above it; measured number outside the range, below it.
By their numbers in this assay, from the lowest: compounds 3, 4 and 2 (each within the scatter of the next); then compound 1.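

In this assay the chain on an oxygen next to a carbonyl group proves sensitive to how its atoms are joined: with the same four carbons, sec-butyl in place of isobutyl gives a number 20 percentage points lower from compound 1 to compound 4 (beyond the scatter) at this one concentration. Until now only the ring nitrogen had shown a step, a number 16 percentage points lower from compound 1 to compound 2 (beyond the scatter), so this second place in compound 1 also responds to a small change, and in the same direction. Nothing on hand accounts for the lower number.

From the compounds shown here alone, it remains open whether the number follows the branching of the chain or its length, which a straight n-butyl, a tert-butyl or a longer chain on the same oxygen would help to separate. Going by these compounds, it also remains open whether sec-butyl has the same effect when a methyl sits on the ring nitrogen.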